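The source may report more compounds than this note shows. Statements on the series, on what has been measured and on what is new or still open speak of the compounds shown alone.

Compound 1 `CC1(C)[C@H]2CC[C@]1(C)N(Cc1cn(-c3ccccc3Br)nn1)C(=O)C2` gives 500 nM in the test below
Compound 2 `CC1(C)[C@H]2CC[C@]1(C)N(Cc1cn(-c3cccc(O)c3)nn1)C(=O)C2` gives 270 nM in the same test

Both numbers come from a functional assay on SGC-7901 cells (Homo sapiens) for inhibition, read by MTT assay, with a stated time of 24 h; a lower number here means a stronger inhibitor, a higher number a weaker inhibitor. With only these two values to compare, compound 2 and compound 1 lie within the scatter of each other, so the pair cannot be ranked.

Compound 3 `COc1ccc(-n2cc(CN3C(=O)C[C@@H]4CC[C@@]3(C)C4(C)C)nn2)cc1` keeps the shared core and changes one group: 4-methoxyphenyl in place of 3-hydroxyphenyl on an aromatic nitrogen. In words, 4-methoxyphenyl stands in place of 3-hydroxyphenyl on an aromatic nitrogen.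

Among the measured compounds shown here, only one measured step bears on this change. For the measured compounds named here, it exchanged a different pair of groups at the same place, and no measured compound carries 4-methoxyphenyl, so it is an imperfect guide. That step is a 1.9-fold lower number from compound 1 to compound 2 (0.27 log units; within the scatter), and it stays within the scatter. On that evidence, no step beyond the scatter is expected in this assay, and no direction can be favoured with confidence. The expected step is a 1.3-fold higher number from compound 2 to compound 3 (0.11 log units; within the scatter), which stays within the scatter. For compound 3 the estimated value is 350 nM, with an expected range from 130 nM to 900 nM, and the measurement can now be compared with it.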

Compound 3, half-maximal inhibitory concentration: 480 nM
Beside the measured number, compound 3's estimate is 1.4-fold (0.14 log units) below it; the range from low to high includes it.
By their numbers in this assay, from the lowest: compounds 2, 3 and 1 (each within the scatter of the next).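

In this assay, among the compounds shown here, replacing 3-hydroxyphenyl with 4-methoxyphenyl on the aromatic nitrogen removes the group's one hydrogen-bond donor and adds one heavy atom, yet it gives a 1.8-fold higher number from compound 2 to compound 3 (0.25 log units; within the scatter) and so no step that can be read as a real change. Comparing 4-methoxyphenyl with 2-bromophenyl at the same place gives a 1.0-fold lower number from compound 1 to compound 3 (0.02 log units; within the scatter) as well, so the three substituted phenyl groups shown here cannot be put in order, and a hydrogen-bond donor on this phenyl ring is not needed for a number in this range. Nothing measured here explains why these three groups cannot be told apart.

On these data alone, all three compounds keep a phenyl ring on this nitrogen, and each differs from the others in both the substituent and its ring position, so the effect of either alone stays unknown; 3-methoxyphenyl, for example, would separate the two when compared with 3-hydroxyphenyl and 4-methoxyphenyl. As far as these compounds go, it also remains open whether a phenyl ring bearing an amine or a carboxylic acid, or a longer alkyl chain in place of the ring, would produce a step beyond the scatter.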